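This account rests on a few compounds, and the source may have more. Where it says the series, first, only, none or still open, it means among the compounds named here.

Measured compounds:
compound 1, `Cc1nc(-c2ccccc2)c(C(=O)N2CCN(c3cccc(C#N)c3)CC2)o1`, gives 39.6 nM in a functional assay on HL-60 cells (Homo sapiens) for inhibition, read by MTT assay, with a stated time of 72 h; a higher number here means a weaker inhibitor, a lower number a stronger inhibitor.
compound 2, `Cc1ccc(N2CCN(C(=O)c3oc(C)nc3-c3ccccc3)CC2)c(C)c1`, gives 101 nM.
compound 3, `Cc1nc(-c2ccccc2)c(C(=O)N2CCN(c3cccc(C)c3C)CC2)o1`, gives 35 nM.

Compound 3 stands at the low end of these three numbers, alongside compound 1: a 1.1-fold lower number from compound 1 to compound 3 (0.05 log units; within the scatter). Only compound 2 is set apart from it: a 2.9-fold lower number from compound 2 to compound 3 (0.46 log units; beyond the scatter). Compound 4, `Cc1nc(-c2ccccc2)c(C(=O)N2CCN(c3ccccc3F)CC2)o1`, differs from compound 3 in one place: 2-fluorophenyl in place of 2,3-dimethylphenyl on an amine nitrogen in a ring. Among the compounds with values here, no measured step brings in a 2-fluorophenyl, so the two steps that bear on this exchange are those just named; both show that swapping the group on this ring nitrogen has shifted the number at most modestly. Compound 4 is therefore expected to move little, the expected step being a 1.4-fold higher number from compound 3 to compound 4 (0.15 log units; within the scatter). Compound 4 is estimated at 50 nM, within 20 nM to 130 nM.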

Compound 4, half-maximal inhibitory concentration: 147 nM
For compound 4 the middle estimate is 2.9-fold (0.47 log units) below the measured one, and the stated range ends below it.
By their numbers in this assay, from the lowest: compounds 3 and 1 (each within the scatter of the next); then compounds 2 and 4 (each within the scatter of the next).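

Compound 4 shows that exchanges on this ring nitrogen do not all stay small, since a 4.2-fold higher number from compound 3 to compound 4 (0.62 log units; beyond the scatter) and a 3.7-fold higher number from compound 1 to compound 4 (0.57 log units; beyond the scatter). The 2-fluorophenyl group instead places compound 4 level with the 2,4-dimethylphenyl of compound 2, as a 1.5-fold higher number from compound 2 to compound 4 (0.16 log units; within the scatter). Nothing available here accounts for this shift. The compounds shown leave open how a plain phenyl would read on this nitrogen, and so whether the fluorine itself matters to the number. They also leave open how a methoxy group, or an amine, on that ring would read.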